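The compounds below may be only part of what the source reports. "The series", "measured", "known", "first", "only" and "open" are said of these compounds alone.

Measured so far:
compound 1 `COc1cc(-c2ccnc3cc(-c4ccc(Cl)cc4)nn23)cc(OC)c1OC` – 2320 nM
compound 2 `COc1cc(-c2ccnc3cc(-c4ccc5cc[nH]c5c4)nn23)cc(OC)c1OC` – 23 nM
compound 3 `COc1cc(-c2ccnc3cc(-c4ccccc4)nn23)cc(OC)c1OC` – 254 nM

In a functional assay on MCF7 cells (Homo sapiens) for inhibition, read by CCK-8 assay, with a stated time of 48 h (on this read-out higher numbers stand for weaker inhibition and lower numbers for stronger inhibition), compound 1 stands highest of these three numbers; the step to the nearest is a 9.1-fold lower number from compound 1 to compound 3 (0.96 log units; beyond the scatter) and to the furthest a 100-fold lower number from compound 1 to compound 2 (2.00 log units; beyond the scatter). Compound 4 `COc1ccc(-c2cc3nccc(-c4cc(OC)c(OC)c(OC)c4)n3n2)cc1` differs from compound 1 by methoxy in place of chloro on an aromatic carbon. For the measured compounds named here, the one measured step that bears on this position is a 9.1-fold lower number from compound 1 to compound 3 (0.96 log units; beyond the scatter), where simply taking the chloro away gave a modest gain; an 11-fold higher number from compound 2 to compound 3 (1.04 log units; beyond the scatter) shows that a larger replacement at that carbon can move the number further. A step of similar or somewhat smaller size than the loss of chloro, toward a lower number, is therefore expected: a 6.6-fold lower number from compound 1 to compound 4 (0.82 log units; beyond the scatter). Compound 4 is estimated at 350 nM, within 80 nM to 1500 nM.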

Compound 4, half-maximal inhibitory concentration: 125 nM
Beside the measured number, compound 4's estimate is 2.8-fold (0.45 log units) above it; measured number inside the range.
By their numbers in this assay, from the lowest: compound 2; then compound 4; then compound 3; then compound 1.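

In this assay, methoxy does far more than merely removing the chloro: a 19-fold lower number from compound 1 to compound 4 (1.27 log units; beyond the scatter) is a larger step than the loss of chloro alone, and a 2.0-fold lower number from compound 3 to compound 4 (0.31 log units; beyond the scatter) shows that methoxy also brings a modest gain over hydrogen on this carbon. Still, a 5.4-fold higher number from compound 2 to compound 4 (0.74 log units; beyond the scatter) leaves the 1H-indol-6-yl group with the lowest number of the four. Nothing available gives a reason for these differences. Open, going by these compounds, is where an amine, a carboxylic acid or a longer chain such as ethoxy at this carbon would fall.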